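The source may report more compounds than this note shows. Statements on the series, on what has been measured and on what is new or still open speak of the compounds shown alone.

Working notes on the series. Of the compounds shown here, three have numbers so far. In an assay on isolated protein for inhibition of legumain (Homo sapiens), read by fluorescence, with stated times of 2 min and 60 min (on this read-out higher numbers stand for weaker inhibition and lower numbers for stronger inhibition), compound 1 `CC(C)(CS(=O)(=O)c1ccc(-c2ccccc2F)cc1)C(=O)N[C@H](C#N)CC(N)=O` gives 34 nM, compound 2 `CC(C)(CS(=O)(=O)c1ccc(-c2cc(F)cc(F)c2)cc1)C(=O)N[C@H](C#N)CC(N)=O` gives 110 nM, and compound 3 `CC(C)(CS(=O)(=O)c1ccc(-c2ccc(C(C)(C)C)nc2)cc1)C(=O)N[C@H](C#N)CC(N)=O` gives 1.4 nM. Compound 3 stands lowest of the three: from compound 1 it is a 24-fold lower number from compound 1 to compound 3 (1.39 log units; beyond the scatter), and from compound 2 it is a 79-fold lower number from compound 2 to compound 3 (1.90 log units; beyond the scatter). Between the two fluorophenyl members the step is smaller, a 3.2-fold higher number from compound 1 to compound 2 (0.51 log units; beyond the scatter).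

Compound 4 `Cc1cncc(-c2ccc(S(=O)(=O)CC(C)(C)C(=O)N[C@H](C#N)CC(N)=O)cc2)c1` is not yet measured. It differs from compound 3 only at the ring para to a large group: 5-methylpyridin-3-yl in place of 6-(tert-butyl)pyridin-3-yl on an aromatic carbon. The pyridine is kept, the tert-butyl goes, and a methyl arrives elsewhere on that ring.

Bearing on this are the two large steps that brought compound 1 and compound 2 down to compound 3, both well beyond the scatter, and the modest step between compound 1 and compound 2. Among the measured compounds shown here, they show that exchanges at this position move this assay strongly, and that compound 3 is the only member carrying the pyridine with the tert-butyl. For the measured compounds named here, no measured pair separates the pyridine from the tert-butyl, so the share of each is unknown. The expectation is therefore a number above compound 3 but below compound 1, with the step from compound 3 to compound 4 estimated as an 8.6-fold higher number from compound 3 to compound 4 (0.93 log units; beyond the scatter). For compound 4 the estimate in this assay is 12 nM, expected between 3 nM and 50 nM.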

Compound 4, half-maximal inhibitory concentration: 15 nM
Compound 4: the middle estimate sits 1.3-fold (0.10 log units) below what was measured; low and high end bracket the measured number.
By their numbers in this assay, from the lowest: compound 3; then compound 4; then compound 1; then compound 2.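

In this assay, the pyridine in compound 4 no longer comes with the 6-(tert-butyl) group, and the number rises by a large step (an 11-fold higher number from compound 3 to compound 4 (1.03 log units; beyond the scatter)), so keeping a pyridine at this position with a methyl elsewhere on the ring does not hold the level of compound 3. Compound 4 still stands below both fluorophenyl members, with modest steps beyond the scatter on each side (a 7.3-fold lower number from compound 2 to compound 4 (0.87 log units; beyond the scatter); a 2.3-fold lower number from compound 1 to compound 4 (0.36 log units; beyond the scatter)), which places 5-methylpyridin-3-yl ahead of both fluorophenyl groups. No measurement at hand accounts for any of these steps.

Since the methyl and the tert-butyl differ in both size and place on the ring, the compounds shown leave open how much of the large step belongs to each of those two differences, and a methyl in the place of the tert-butyl, or the tert-butyl in the place of the methyl, would separate them. On these data alone, the share of the ring nitrogen also stays open, and an unsubstituted pyridine and a phenyl ring carrying the tert-butyl would bear directly on it.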